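A few compounds are considered here, and "the series" means these few. Any claim that something is new, unique, unknown or untested is made for them only; others in the source may bear on it.

Among the compounds with values here, three esters have been taken into a functional assay on BeWo cells (Homo sapiens) for inhibition, read by MTT assay (a higher number here means a weaker inhibitor, a lower number a stronger inhibitor), so far, and only two gave numbers. Compound 1 (`CC1(C)C2CCC1(C)C(OC(=O)/C=C/c1ccc(O)c(O)c1[N+](=O)[O-])C2`) gives 9310 nM in this assay as its inhibition read-out. Compound 2 (`O=C(/C=C/c1cc(O)c(O)c([N+](=O)[O-])c1)OCCc1ccccc1`) has the entry "not determined" (no result reported) and offers nothing to compare. Compound 3 (`CC1(C)C2CCC1(C)C(OC(=O)/C=C/c1cc(O)c(O)c(Br)c1)C2`) gives 20000 nM and so holds the higher of the two numbers, which makes it the weaker inhibitor of the pair. Compound 1 is its nearest neighbour, and the gap between them lies beyond the usual scatter.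

Compound 4 (`CC1(C)C2CCC1(C)C(OC(=O)/C=C/c1ccc(O)c(O)c1)C2`) is still unmeasured. It differs from compound 3 in one place: hydrogen in place of bromo on an aromatic carbon. Within the data shown here, no measured pair isolates this change, and compounds 1 and 3 differ in more than one place, so their gap cannot serve as a direct guide. Among the measured compounds shown here, the only lean comes from compound 1 at 9310 nM, which sits lower than compound 3 and weakly favours a lower number. The expected change a 1.7-fold lower number from compound 3 to compound 4 (0.22 log units; within the scatter) is therefore small, and it may well stay within the scatter. For compound 4 the estimated value is 12000 nM, with an expected range (4500 nM to 32000 nM).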

Compound 4, half-maximal inhibitory concentration: 35900 nM
Compound 4: middle estimate off by 3.0-fold (0.48 log units), on the low side; the whole stated range lies below it.
By their numbers in this assay, from the lowest: compound 1; then compounds 3 and 4 (each within the scatter of the next).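

In this assay, within the data shown here, replacing bromo with hydrogen on the aromatic carbon ortho to a hydroxy group gives a 1.8-fold higher number from compound 3 to compound 4 (0.25 log units; within the scatter) and provides the first single-place reading at this position: bromo and hydrogen cannot be told apart here. Among these compounds, replacing nitro with hydrogen on an aromatic carbon is a different matter, with a 3.9-fold higher number from compound 1 to compound 4 (0.59 log units; beyond the scatter) as a modest step that is the only single-place change to exceed the scatter, so the nitro group of compound 1 marks a real difference from compound 4 where the bromo group of compound 3 does not. Nothing available on these compounds bears on the reason for either outcome.

Still open, on these data alone, is whether any group on the aromatic carbon held by bromo in compound 3 can move the number beyond the scatter, with chloro, methoxy or an amine as untested replacements. Also open, as far as these compounds go, is whether the step from nitro to hydrogen keeps its size when the ester part of the shared core is replaced by a longer chain or a carboxylic acid is introduced.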